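The source may hold more compounds than are shown below. What is called first, only, known or untested is meant among the compounds shown, and "the series" means these compounds.

Two compounds with a shared core carrying an amino-substituted anilide have been measured in a functional assay on A-375 cells (Homo sapiens) for inhibition, read by CCK-8 assay, with a stated time of 72 h, tested at 8 uM; a higher number here means more inhibition of growth at the concentration tested, a lower number less inhibition of growth. Compound 1, `Nc1ccccc1NC(=O)/C=C/c1ccc(CSc2ccc(Cl)cc2)cc1`, gives 48.2% in this assay. Compound 2, `Nc1ccccc1NC(=O)c1ccc(CSc2cccc(F)c2)cc1`, gives 76.3% in this assay. Compound 1 thus stands lowest of the two numbers, with compound 2 above it by a gap that lies beyond the usual scatter; the two compounds differ in more than one place, so no single change can be tied to that gap.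

The unmeasured compound 3, `Nc1ccccc1NC(=O)/C=C/c1ccc(CSc2cccc3ccccc23)cc1`, differs from compound 1 in a single place: naphthalen-1-yl in place of 4-chlorophenyl on a sulfur. For the measured compounds named here, the only measured pair offers no step that isolates a change of this kind on the sulfur-bearing position, so there is no direct guide to how large the effect of this swap should be.

Without such a guide, the step from compound 1 to compound 3 is expected to be small, around a number 3.8 percentage points higher from compound 1 to compound 3 (within the scatter), with either direction possible and no change beyond the scatter the most likely outcome. Compound 3 is therefore estimated at 52%, within a range of 30% to 75%.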

Compound 3, percent growth inhibition at one concentration: 36%
Compound 3: the middle estimate sits 16 percentage points above what was measured; the range from low to high includes it.
By their numbers in this assay, from the lowest: compound 3; then compound 1; then compound 2.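

For the compounds shown here, the swap of naphthalen-1-yl in place of 4-chlorophenyl on a sulfur gives a number 12.2 percentage points lower from compound 1 to compound 3 (beyond the scatter), and it is the first step that changes this group alone, showing that growth inhibition in this assay responds to what this position carries. The change is not a simple one, since 7 heavy atoms with one aromatic ring and a chlorine leave and 10 carbon atoms in 2 aromatic rings enter, so this single step cannot say whether the drop follows from the added ring or from the lost chlorine. No measurement at hand explains the drop.

As far as these compounds go, whether a plain phenyl group on the sulfur would stand nearer to compound 1 or to compound 3 remains open, and that comparison would begin to separate the ring from the chlorine. Also open, from the compounds shown here alone, is what a group of a different kind would do in this place, such as a carboxylic acid or an amine on a short chain, while compound 2 differs from compound 1 in more than one place and cannot settle either question.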